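The source may hold more compounds than are shown below. What is called first, only, known or untested is meant among the compounds shown, and "the series" means these compounds.

Compound 2 `C(=C\C1CCCN(CCCOc2ccccc2)C1)\c1ccccc1` gives 15 nM in an assay on isolated protein for binding affinity to Sigma non-opioid intracellular receptor 1 (Rattus norvegicus); a higher number here means a weaker inhibitor, a lower number a stronger inhibitor. It stands level with compound 3 `O=C(CCCN1CCCC(/C=C\c2ccccc2)C1)c1ccccc1`, which gives 15 nM, the two together the highest of the three numbers, while compound 1 `C(=C\C1CCCN(CCC2CCCCC2)C1)\c1ccccc1` gives 7 nM. The two measured steps, a 2.1-fold higher number from compound 1 to compound 2 (0.33 log units; beyond the scatter) and no change at the digits printed from compound 2 to compound 3 (within the scatter), both alter the side chain on the ring nitrogen, and neither is large. Compound 4 `C(=C/C1CCCN(CCCOc2ccccc2)C1)\c1ccccc1` differs from compound 2 elsewhere: the two compounds have the same atoms and bonds; at least one stereo element is drawn with a configuration in one of them and without one in the other: 1 of 2 stereo elements differ; a double bond is drawn Z in compound 2 and E in compound 4. Among the compounds with values here, no measured step touches the geometry of that double bond, so the measured steps give no direct guide, and only the general small spread of the three numbers can be drawn on. The expected step is therefore a 1.3-fold higher number from compound 2 to compound 4 (0.12 log units; within the scatter), with the direction uncertain. Compound 4 is estimated at 20 nM, within 6 nM to 70 nM.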

Compound 4, half-maximal inhibitory concentration: 33 nM
Compound 4: middle estimate off by 1.7-fold (0.22 log units), on the low side, within the range that was stated.
By their numbers in this assay, from the lowest: compound 1; then compounds 2 and 3 (each within the scatter of the next); then compound 4.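

In this assay, the geometry of the double bond has a measurable effect, with a 2.2-fold higher number from compound 2 to compound 4 (0.34 log units; beyond the scatter). The earlier steps all altered the side chain on the ring nitrogen, whereas this one keeps every atom and bond and changes only Z to E. One caution applies to this comparison: the fact that one of compounds 2 and 4 is drawn with a defined configuration and the other without, at the place where they differ

Still open, going by these compounds, is whether the same change from Z to E would act alike with the cyclohexyl side chain of compound 1 or the benzoyl side chain of compound 3. Also open, on these data alone, is what a longer chain carrying the phenoxy group would give with either geometry.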